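Ether analogue of the hydroxy ester in the DU-145 series

The compounds below may be only part of what the source reports. "The series", "measured", "known", "first", "only" and "open" are said of these compounds alone.

Among the measured compounds shown here, compound 3 `CC(C)=CC[C@@H](OC(=O)CCO)C1=CC(=O)c2c(O)ccc(O)c2C1=O` gives the highest number of the three measured members in a functional assay on DU-145 cells (Homo sapiens) for cytotoxicity, read by MTT assay (on this read-out lower numbers stand for stronger inhibition and higher numbers for weaker inhibition), at 55300 nM. Its nearest neighbour is compound 2 `CCC(CO[C@H](CC=C(C)C)C1=CC(=O)c2c(O)ccc(O)c2C1=O)OC(C)=O`, which gives 25400 nM; the furthest is compound 1 `CC(C)=CC[C@@H](OC(=O)C1CCCO1)C1=CC(=O)c2c(O)ccc(O)c2C1=O`, which gives 10500 nM. The step from the oxolane ester to the hydroxy ester was a 5.3-fold higher number from compound 1 to compound 3 (0.72 log units; beyond the scatter), and the step from the acetoxy ether to the hydroxy ester was a 2.2-fold higher number from compound 2 to compound 3 (0.34 log units; beyond the scatter).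

Compound 4 `CCC(O)CO[C@H](CC=C(C)C)C1=CC(=O)c2c(O)ccc(O)c2C1=O` is the next member. The change from compound 3 is 2-hydroxybutyl in place of (2-hydroxyethyl)carbonyl on an oxygen on a saturated carbon. It removes the carbonyl that compound 3 shares with compound 1, and gives an ether of the same kind as in compound 2, but with the hydroxyl free rather than acetylated. The step from compound 2 to compound 3, a 2.2-fold higher number from compound 2 to compound 3 (0.34 log units; beyond the scatter), is the one that bears most directly, since it compared an ether with an ester on the same oxygen; it was modest. Reversing that kind of change is expected to bring the number back down by a similarly modest amount, though the free hydroxyl has no direct precedent among the ethers here. Compound 4 is therefore expected to give about 30000 nM in this assay, within a range of 12000 nM to 75000 nM, which means an expected step of a 1.8-fold lower number from compound 3 to compound 4 (0.27 log units; within the scatter).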

Compound 4, half-maximal inhibitory concentration: 16400 nM
Compound 4: the middle estimate sits 1.8-fold (0.26 log units) above what was measured, within the range that was stated.
By their numbers in this assay, from the lowest: compounds 1, 4 and 2 (each within the scatter of the next, the first and the last beyond it); then compound 3.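

In this assay, the exchange of (2-hydroxyethyl)carbonyl for 2-hydroxybutyl on this oxygen gives a 3.4-fold lower number from compound 3 to compound 4 (0.53 log units; beyond the scatter), which leaves compound 3 as the weakest of the four and shows that a free hydroxyl on the substituent does not by itself go with the high number. Hydrogen in place of acetyl on the ether gives a 1.5-fold lower number from compound 2 to compound 4 (0.19 log units; within the scatter), so at this side-chain oxygen the two ethers are not separated by this read-out, a comparison the earlier compounds could not offer. The oxolane ester and the hydroxybutyl ether are likewise not separated, at a 1.6-fold higher number from compound 1 to compound 4 (0.19 log units; within the scatter), so the carbonyl alone does not set the number here: compound 1 carries one and stays level with the ether compound 4, while compound 3 also carries one and lies beyond the scatter of both. Nothing at hand bears on the reason for these differences.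

As far as these compounds go, whether an amine or a carboxylic acid in place of the hydroxyl of the 2-hydroxybutyl would shift the number remains open, as does the effect of a longer chain on the same oxygen. Also open, from the compounds shown here alone, is how an oxolan-2-ylmethyl ether, the direct partner of the ester in compound 1, would compare.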